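The source may hold more compounds than are shown below. What is called first, only, known or untested is meant among the compounds shown, and "the series" means these compounds.

Series notes. The shared core is that of compound 1 `CCCCCCCCOc1nc(N)nc2c1ncn2/C=C1/CC1(CO)CO`; compound 2 `CCCCCOc1nc(N)nc2c1ncn2/C=C1/CC1(CO)CO`, compound 3 `CCCCCCSc1nc(N)nc2c1ncn2/C=C1/CC1(CO)CO` and compound 4 `CCOc1nc(N)nc2c1ncn2/C=C1/CC1(CO)CO` differ from it only in the group on the aromatic carbon. In an ADME assay on HFF cells (Homo sapiens) for cytotoxicity, with a stated time of 8 days (on this read-out lower numbers stand for higher toxicity in this test and higher numbers for lower toxicity in this test), compound 1 sits at a limit of the assay, > 300000 nM. Compound 2 gives 259000 nM in this assay. Compound 3 likewise reaches only a limit, > 300000 nM, in this assay. Where compound 3 stands is thus known only as a limit, one of two such values (the limit of > 300000 nM in this assay, at which 2 of the 3 values shown sit). Compound 4 is not yet measured; it differs from compound 3 by ethoxy in place of hexylsulfanyl on an aromatic carbon. Among the compounds with values here, the steps that bear on this are an at least 1.1-fold higher number from compound 2 to compound 3 (0.06 log units; that floor lies within the scatter) and an at least 1.1-fold lower number from compound 1 to compound 2 (0.06 log units; that floor lies within the scatter), both within the scatter. For compound 4 no step beyond the scatter is therefore expected in this assay, an at least 1.0-fold lower number from compound 3 to compound 4 (0.02 log units; that floor lies within the scatter). Compound 4 is estimated at 280000 nM, between 120000 nM and 650000 nM.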

Compound 4, half-maximal cytotoxic concentration: > 300000 nM
Compound 4: only a limit was reported; the forecaster's own chance of this, stated with the estimate: 55%; middle value at least 1.0-fold (0.02 log units) away from the limit.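

In this assay, the ethoxy chain of compound 4 also ends at the assay limit, so this position now shows no measurable cytotoxicity with a far shorter chain as well as with octyloxy and hexylsulfanyl. Shortening pentyloxy to ethoxy gives an at least 1.1-fold higher number from compound 2 to compound 4 (0.06 log units; that floor lies within the scatter). The steps to compound 4 from compound 1 and compound 3 cannot be read, and the series now sits mostly at one limit: the limit of > 300000 nM in this assay, at which 3 of the 4 values shown sit.

Going by these compounds, it remains open whether an amine or a carboxylic acid on this aromatic carbon would give a value within the assay's range. On these data alone, how far compound 1, compound 3 and compound 4 differ beyond the limit also remains open.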